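The source may hold more compounds than are shown below. What is called first, only, known or untested is meant among the compounds shown, and "the series" means these compounds.

Compound 1 `CC(O)(CS(=O)(=O)c1ccc(S(F)(F)(F)(F)F)cc1)C(=O)Nc1ccc(C#N)cc1C(F)(F)F` and compound 2 `CC(O)(CS(=O)(=O)c1cccc(S(F)(F)(F)(F)F)c1)C(=O)Nc1ccc(C#N)cc1C(F)(F)F` are built from the same atoms joined differently; the difference between the two cores is not broken down here. In a functional assay on CWR22R cells (Homo sapiens) for antiproliferative activity, read by propidium iodide staining, with a stated time of 96 h (on this read-out lower numbers stand for stronger inhibition and higher numbers for weaker inhibition), compound 1 gives 19400 nM, and compound 2 gives 14300 nM. Compound 3 `CC(O)(CS(=O)(=O)c1ccc(S(F)(F)(F)(F)F)cc1)C(=O)Nc1ccc([N+](=O)[O-])cc1C(F)(F)F` carries on the core of compound 1 the change (nitro in place of cyano on an aromatic carbon); in this assay compound 3 gives 18700 nM, so that the step was a 1.0-fold lower number from compound 1 to compound 3 (0.02 log units; within the scatter). Compound 4 `CC(O)(CS(=O)(=O)c1cccc(S(F)(F)(F)(F)F)c1)C(=O)Nc1ccc([N+](=O)[O-])cc1C(F)(F)F` carries the same change on the core of compound 2, namely (nitro in place of cyano on an aromatic carbon). The expectation for compound 4 rests on that earlier step, because a 1.0-fold lower number from compound 1 to compound 3 (0.02 log units; within the scatter) stayed within the scatter, and the same is expected here as a 1.0-fold lower number from compound 2 to compound 4 (0.01 log units; within the scatter). Compound 4 is therefore expected to give about 14000 nM in this assay, between 7000 nM and 28000 nM.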

Compound 4, half-maximal inhibitory concentration: 100000 nM
Estimate against measurement, compound 4: 7.1-fold (0.85 log units) below; measured number outside the range, above it.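

Nitro in place of cyano on an aromatic carbon gave a 7.0-fold higher number from compound 2 to compound 4 (0.84 log units; beyond the scatter) in this assay, and the same change did not carry over alike from one core to the other: the same change on two cores in this assay, a 1.0-fold lower number (0.02 log units; within the scatter) from compound 1 to compound 3 and a 7.0-fold higher number (0.84 log units; beyond the scatter) from compound 2 to compound 4, 7.3-fold (0.86 log units) apart, beyond the scatter of two such steps. The outcome on the core of compound 1 therefore did not foretell the outcome on the core of compound 2. This does not show why the two cores part ways, and two cores give no rule for a third.

The compounds shown leave open how other groups in that place, such as an amine or a carboxylic acid, would read on these two cores. Also open, on these data alone, is whether a chlorine in place of the trifluoromethyl group would keep the same difference between the cores.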